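Salicylamide imides: L6 cytotoxicity notes, one replacement pending

The source may report more compounds than this note shows. Statements on the series, on what has been measured and on what is new or still open speak of the compounds shown alone.

Measured so far:
compound 1 `CS(=O)(=O)c1ccc(C(=O)NC(=O)c2ccccc2O)cc1`: > 100 ug/mL
compound 2 `O=C(NC(=O)c1ccc(Cl)cc1Cl)c1ccccc1O`: 62 ug/mL

In an ADME assay on L6 cells (Rattus norvegicus) for cytotoxicity, read by resazurin assay, with a stated time of 72 h (on this read-out higher numbers stand for weaker inhibition and lower numbers for stronger inhibition), compound 1 reaches only the assay limit, > 100 ug/mL, so no number is available for it. Compound 2 gives 62 ug/mL in this assay. Of the two values shown, compound 1 sits at the limit of > 100 ug/mL in this assay, at which 1 of the 2 values shown sits, and compound 2 sits below it as a measured number; with one value a limit, nothing beyond that is read from the pair.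

Compound 3 `COC(=O)CCC(=O)Nc1ccc(C(=O)NC(=O)c2ccccc2O)cc1` is not yet measured in this assay. It differs from compound 1 in one place: ((2-(methoxycarbonyl)ethyl)carbonyl)amino in place of methylsulfonyl on an aromatic carbon. The shared core of compound 1 is kept, the change being confined to the group on the aromatic carbon para to the large group.

For compound 3 the expected step of a number no higher from compound 1 to compound 3 (the limit leaves the size open) in this assay is none beyond the usual scatter, and cytotoxicity on L6 cells is expected to remain weak. Compound 3 is therefore estimated at 100 ug/mL, with a range from 50 ug/mL to 200 ug/mL, and a fair chance that this assay again returns only a limit.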

Compound 3, half-maximal inhibitory concentration: > 50 ug/mL
Compound 3: no number, only a limit (the forecaster's own chance of this, stated with the estimate: 55%); the middle value does not contradict the limit.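

In this assay compound 3 gives > 50 ug/mL, which is a limit and not a number. Going by these compounds alone, compound 1 likewise stands at a limit, > 100 ug/mL, so no step between compound 1 and compound 3 can be read. From the compounds shown here alone, whether ((2-(methoxycarbonyl)ethyl)carbonyl)amino in place of methylsulfonyl changes cytotoxicity on L6 cells at all, and in which direction, remains open.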